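Chalcogen variations on a shared core: growth inhibition notes

A few compounds are considered here, and "the series" means these few. Any claim that something is new, unique, unknown or untested is made for them only; others in the source may bear on it.

Measured so far:
compound 1 `CS/C(=N\C(=O)c1ccno1)NC(=O)c1ccno1` — in a functional assay on MCF7 cells (Homo sapiens) for cytotoxicity, read by MTT assay, with a stated time of 72 h (on this read-out lower numbers stand for stronger inhibition of growth and higher numbers for weaker inhibition of growth), compound 1 gives > 100000 nM, a limit.
compound 2 `O=C(/N=C(/NC(=O)c1ccno1)[Se]Cc1ccccc1)c1ccno1` — in this assay compound 2 gives > 100000 nM, a limit.

Compound 2 stands only as a limit in this assay. Both measured values sit at the limit of > 100000 nM in this assay, at which 2 of the 2 values shown sit, so the step that the two limits leave unreadable from compound 1 to compound 2 cannot be read in either direction. Compound 3 `C[Se]/C(=N\C(=O)c1ccno1)NC(=O)c1ccno1` differs from compound 2 by hydrogen in place of phenyl on a saturated chain carbon bound to a selenium atom. For the measured compounds named here, no measured step touches this change, and the one step that exists is unreadable, so it gives no size and no direction to carry over. The expected step of a number no higher from compound 2 to compound 3 (the limit leaves the size open) is none beyond the scatter. The estimate for compound 3 is 100000 nM, ranging from 30000 nM to 300000 nM, most likely reported again as a limit.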

Compound 3, concentration for total growth inhibition: 57500 nM
Beside the measured number, compound 3's estimate is 1.7-fold (0.24 log units) above it; the range from low to high includes it.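

In this assay, for the compounds shown here, compound 3 gives the first number that is not a limit, so two changes now have a floor. Hydrogen in place of phenyl on a saturated chain carbon bound to a selenium atom reads as an at least 1.7-fold lower number from compound 2 to compound 3 (0.24 log units; that floor lies within the scatter), and selenium in place of sulfur reads as an at least 1.7-fold lower number from compound 1 to compound 3 (0.24 log units; that floor lies within the scatter). Both steps start from a limit, so neither size is fixed: the limit of > 100000 nM in this assay, at which 2 of the 3 values shown sit.

From the compounds shown here alone, the true size of both steps stays open, and the step between the two limits cannot be read. Going by these compounds, how an ethyl chain on selenium, or an amine in place of the selenium group, would read also remains open.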